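The source may hold more compounds than are shown below. What is called first, only, known or untested is meant among the compounds shown, and "the series" means these compounds.

Measured compounds:
compound 1 `CCCCN(c1nc2c(NS(C)(=O)=O)cccc2o1)[C@H](C)c1ccc(-c2ccccc2-c2nnn[nH]2)cc1` — 73.8 ng.h/mL
compound 2 `Cc1ccc(-c2nc(=O)o[nH]2)c(-c2ccc([C@@H](C)N(CC3CC3)c3nc4c(C(=O)O)cccc4o3)cc2)c1` — 4830 ng.h/mL

In an ADME assay on the whole organism (Macaca fascicularis) for pharmacokinetics, read by LC-MS, using cassette dosing, at a dose of 1 mg/kg by the oral route (on this read-out higher numbers stand for higher exposure at the dose given and lower numbers for lower exposure), compound 1 gives 73.8 ng.h/mL, the lowest of the two numbers, while compound 2 gives 4830 ng.h/mL, far beyond the scatter from compound 1. Going by the values given here, no single-change step between measured compounds is available. Compound 3 `CCCCN(c1nc2c(C(=O)N(C)C)cccc2o1)[C@H](C)c1ccc(-c2ccccc2-c2nnn[nH]2)cc1` differs from compound 1 in one place: dimethylcarbamoyl in place of methanesulfonamido on an aromatic carbon. Among the compounds with values here, with only the low exposure of compound 1 and no matched step to lean on, a modest rise is expected, and the step of a 2.7-fold higher number from compound 1 to compound 3 (0.43 log units; beyond the scatter) is the estimate for that change. Compound 3 is therefore expected to give about 200 ng.h/mL, within a range from 40 ng.h/mL to 1000 ng.h/mL.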

Compound 3, area under the concentration-time curve: 104 ng.h/mL
Estimate against measurement, compound 3: 1.9-fold (0.28 log units) above; measured number inside the range.
By their numbers in this assay, from the lowest: compounds 1 and 3 (each within the scatter of the next); then compound 2.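

In this assay, going by these compounds alone, dimethylcarbamoyl in place of methanesulfonamido on this aromatic carbon gives a 1.4-fold higher number from compound 1 to compound 3 (0.15 log units; within the scatter), the first single-change reading at this position. Here, the exchange of these two groups, including loss of the hydrogen-bond donor counted for methanesulfonamido, does not separate compound 3 from compound 1. No measurement shown bears on this result. Going by these compounds, whether an amine or a methoxy group at this position on the core of compound 1 would give a number beyond the scatter remains open. Compound 2 differs from compound 1 in more than one place, so no single part can be tied to its number.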